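Ester for hydrazide at the carbonyl: tolerated dose outlook

The compounds below may be only part of what the source reports. "The series", "measured", "known", "first", "only" and "open" are said of these compounds alone.

Three compounds of the shared core have been run in an ADME assay on TZM cells (Homo sapiens) for cytotoxicity, read by XTT assay, with a stated time of 4 days; a lower number here means that less compound is tolerated, a higher number that more compound is tolerated. Compound 1 `Cc1cc(N)cc(C)c1Oc1cc(Nc2ccc(C#N)cc2)c(N)cc1C(F)(F)F` gives 15800 nM, and compound 3 `Cc1cc(/C=C/C#N)cc(C)c1Oc1cc(Nc2ccc(C#N)cc2)c(N)cc1C(=O)O` gives 14900 nM; the two values sit within the scatter of each other, so no order is drawn between them. Compound 2 `Cc1cc(CCC#N)cc(C)c1Oc1cc(Nc2ccc(C#N)cc2)c(N)cc1C(=O)NN` stands apart from these only in that this assay returns for it a limit rather than a number, > 22700 nM. Among the measured compounds shown here, the limit of > 22700 nM in this assay, at which 1 of the 3 values shown sits, is the highest point the series reaches, so for compound 2 only a range is known, and no measured step to any other compound can be written down.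

Compound 4 `COC(=O)c1cc(N)c(Nc2ccc(C#N)cc2)cc1Oc1c(C)cc(CCC#N)cc1C` has not yet been measured. It differs from compound 2 in one place: methoxy in place of aminoamino on a carbonyl carbon. The aminoamino on the carbonyl carbon, whose other neighbour is an aromatic carbon, is replaced by methoxy; one bond further out the change reads aminocarbamoyl to methoxycarbonyl.

For the measured compounds named here, nothing among the measured compounds tracks this exchange, so the expected step in this assay is none beyond the scatter, with at most a slight lean toward a lower number, that is, less compound tolerated. The estimated step from compound 2 to compound 4 is an at least 1.2-fold lower number from compound 2 to compound 4 (0.10 log units; that floor lies within the scatter). Compound 4 is accordingly expected to give about 18000 nM, within 7000 nM to 45000 nM, with a fair chance that this assay again reports only a limit.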

Compound 4, half-maximal cytotoxic concentration: > 22700 nM
Compound 4: a limit, no number; the forecaster's own chance of this, stated with the estimate: 30%; middle value at least 1.2-fold (0.10 log units) from the limit.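

Compound 4 gives only a limit in this assay, > 22700 nM, and compound 2 gives only a limit too, so no step can be read between compound 2 and compound 4: the limit of > 22700 nM in this assay, at which 2 of the 4 values shown sit.

The compounds shown leave open whether methoxy and aminoamino on this carbonyl carbon differ at all in the tolerated concentration, and what number either compound would give.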